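A few compounds are considered here, and "the series" means these few. Any claim that something is new, unique, unknown or untested is made for them only; others in the source may bear on it.

Measured in a functional assay on SW480 cells (Homo sapiens) for antiproliferative activity, read by sulforhodamine B assay, with a stated time of 48 h; on this read-out higher numbers stand for weaker inhibition and lower numbers for stronger inhibition:
- compound 1 `COc1cccc(/C=C/C(=O)C(=Cc2ccc(O)c(F)c2)C(=O)/C=C/c2cccc(OC)c2OC)c1OC`: 330 nM
- compound 2 `COc1cc(C=C(C(=O)/C=C/c2cccc(OC)c2OC)C(=O)/C=C/c2cccc(OC)c2OC)cc(OC)c1O`: 420 nM
- compound 3 `COc1ccc(OC)c(/C=C/C(=O)C(=Cc2ccc(O)c(OC)c2)C(=O)/C=C/c2cc(OC)ccc2OC)c1`: 410 nM

Compound 3 lies within the usual scatter of both other compounds, so these three values cannot be ranked. Compound 4 `COc1ccc(OC)c(/C=C/C(=O)C(=Cc2ccc(OC)c(OC)c2)C(=O)/C=C/c2cc(OC)ccc2OC)c1` differs from compound 3 in one place: methyl in place of hydrogen on an oxygen on an aromatic ring. This is hydroxy to methoxy, which turns 4-hydroxy-3-methoxyphenyl into 3,4-dimethoxyphenyl. Among the compounds with values here, the only measured step, a 1.3-fold higher number from compound 1 to compound 2 (0.10 log units; within the scatter), changes the same aromatic group but keeps its hydroxy, so it bears on this change only indirectly. Within the data shown here, no measured compound shows the effect of methyl in place of that hydrogen, so no shift beyond the scatter is expected, though this is uncertain. The expected change is a 1.2-fold higher number from compound 3 to compound 4 (0.09 log units; within the scatter). The estimated value for compound 4 is 500 nM, with an expected range of 200 nM to 1300 nM.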

Compound 4, half-maximal inhibitory concentration: 560 nM
For compound 4 the middle estimate is 1.1-fold (0.05 log units) below the measured one; the measured number falls inside the stated range.
By their numbers in this assay, from the lowest: compounds 1, 3, 2 and 4 (each within the scatter of the next).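

Methyl in place of hydrogen on this oxygen, the hydroxy to methoxy change, gives a step (a 1.4-fold higher number from compound 3 to compound 4 (0.14 log units; within the scatter)) in this assay that stays within the scatter. For this pair, then, the free hydroxy is not needed: 3,4-dimethoxyphenyl cannot be told apart from 4-hydroxy-3-methoxyphenyl. No available data explain this result. Going by these compounds, whether a longer chain on this oxygen, such as ethyl or benzyl, or an amine or a carboxylic acid in place of the hydroxy, would move the number beyond the scatter stays open.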